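Diaryl urea series: a difluorophenyl in place of trifluoromethylphenyl

The source may report more compounds than this note shows. Statements on the series, on what has been measured and on what is new or still open speak of the compounds shown alone.

Measured compounds:
Compound 1 `Cn1ncnc1-c1cc(Oc2ccc(NC(=O)Nc3cccc(C(F)(F)F)c3)cc2F)ccn1` reaches only the limit > 50000 nM in a functional assay on HT-29 cells (Homo sapiens) for antiproliferative activity, read by MTT assay, with a stated time of 72 h (a higher number here means a weaker inhibitor, a lower number a stronger inhibitor), which is not a number.
Compound 2 `CN(C)CCn1cnnc1-c1cc(Oc2ccc(NC(=O)Nc3ccc(F)c(F)c3)cc2F)ccn1` gives 3620 nM in this assay.
Compound 3 `CCN(CC)CCn1cnnc1-c1cc(Oc2ccc(NC(=O)Nc3cccc(C(F)(F)F)c3)cc2F)ccn1` gives 630 nM in this assay.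

Compound 3 holds the lowest number of the two that were measured as numbers; compound 2 sits a good deal higher, beyond the scatter, and compound 1 stops at a limit (the limit of > 50000 nM in this assay, at which 1 of the 3 values shown sits). For the measured compounds named here, the one step between compounds that differ in a single place, an at least 79-fold lower number from compound 1 to compound 3 (1.89 log units; beyond the scatter), shows that the 4-(2-(diethylamino)ethyl)-4H-1,2,4-triazol-3-yl group carries a large gain over the 1-methyl-1H-1,2,4-triazol-5-yl group.

Compound 4 `CCN(CC)CCn1cnnc1-c1cc(Oc2ccc(NC(=O)Nc3ccc(F)c(F)c3)cc2F)ccn1` keeps everything of compound 3 except one change: 3,4-difluorophenyl in place of 3-(trifluoromethyl)phenyl on an amide-type nitrogen. Going by the values given here, no measured step isolates this change. Compound 2 also carries the 3,4-difluorophenyl, but it differs from compound 3 in two places, so its higher number only hints that the difluorophenyl may cost potency. On that hint, compound 4 is expected to be somewhat weaker than compound 3, with an estimated step of a 2.4-fold higher number from compound 3 to compound 4 (0.38 log units; beyond the scatter). The estimate for compound 4 is 1500 nM, within a range from 500 nM to 5000 nM.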

Compound 4, half-maximal inhibitory concentration: 1240 nM
Beside the measured number, compound 4's estimate is 1.2-fold (0.08 log units) above it, and the stated range covers the measured number.
By their numbers in this assay, from the lowest: compounds 3 and 4 (each within the scatter of the next); then compound 2. At a limit, above all of these: compound 1.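

With the 4-(2-(diethylamino)ethyl)-4H-1,2,4-triazol-3-yl group held fixed, placing 3,4-difluorophenyl in place of 3-(trifluoromethyl)phenyl on the amide-type nitrogen gives a 2.0-fold higher number from compound 3 to compound 4 (0.29 log units; within the scatter) in this assay, so this single change does not separate the two compounds. For the compounds shown here, the earlier hint that the difluorophenyl costs potency therefore finds no support in the one pair that isolates it. With the 3,4-difluorophenyl held fixed, diethylamino in place of dimethylamino on the chain gives a 2.9-fold lower number from compound 2 to compound 4 (0.47 log units; beyond the scatter), a modest step, so the choice of amine on this chain does move the number.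

As far as these compounds go, how a plain phenyl or a 4-chloro-3-(trifluoromethyl)phenyl on the same nitrogen would compare remains open, as does the effect of a pyrrolidine or a morpholine in place of the diethylamino group, or of a longer chain. Nothing among the measurements shown explains why either change has the size it has.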